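A few compounds are considered here, and "the series" means these few. Any claim that something is new, unique, unknown or untested is made for them only; others in the source may bear on it.

Compound 1, `COc1ncc(-c2ccc3nc(NC(=O)NCCN4CCCCC4)sc3c2)cc1NS(=O)(=O)c1ccc(F)cc1`, is the weaker of the two compounds for which a number is in hand. In a functional assay on HCT-116 cells (Homo sapiens) for antiproliferative activity, read by MTT assay, with a stated time of 72 h (a higher number here means a weaker inhibitor, a lower number a stronger inhibitor), compound 1 gives 610 nM. The other measured compound, compound 2, `CCN(CC)CCNC(=O)Nc1nc2ccc(-c3cnc(OC)c(NS(=O)(=O)c4ccc(C)cc4)c3)cc2s1`, differs from compound 1 at more than one place, so its value can only be set alongside: in this assay compound 2 gives 180 nM, a lower number than compound 1 by a gap that lies beyond the scatter of repeated measurements.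

Compound 3, `COc1ncc(-c2ccc3nc(NC(=O)NCCN4CCN(C)CC4)sc3c2)cc1NS(=O)(=O)c1ccc(F)cc1`, has not been measured. It keeps the whole core of compound 1 and changes only the ring at the end of the side chain: 4-methylpiperazin-1-yl in place of piperidin-1-yl on a saturated chain carbon, two bonds along the chain from an amide-type nitrogen. Among the compounds with values here, no measured pair shows the effect of this particular exchange, so nothing in the data fixes its size or direction. A change of this kind, at the far end of a flexible chain, is expected to move the number little, and a step from compound 1 to compound 3 of a 1.2-fold lower number from compound 1 to compound 3 (0.09 log units; within the scatter), within the scatter, is the estimate. Compound 3 is therefore expected to give about 500 nM in this assay, with a range from 200 nM to 1300 nM.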

Compound 3, half-maximal inhibitory concentration: 540 nM
The estimate for compound 3 lay 1.1-fold (0.03 log units) below the measured number; the range from low to high includes it.
By their numbers in this assay, from the lowest: compound 2; then compounds 3 and 1 (each within the scatter of the next).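

Exchanging piperidin-1-yl for 4-methylpiperazin-1-yl on a saturated chain carbon, two bonds along the chain from an amide-type nitrogen, now has a direct reading: in this assay the exchange gives a 1.1-fold lower number from compound 1 to compound 3 (0.05 log units; within the scatter), a step that lies within the scatter of repeated measurements. In this one pair, with the core of compound 1 held fixed, the second ring nitrogen and the methyl group on it, which bring one more heavy atom and one more hydrogen-bond acceptor, leave the two numbers impossible to tell apart. No measurement of any other property of these compounds is available to account for this result.

As far as these compounds go, whether a morpholin-4-yl ring, a carboxylic acid or a longer chain at this end of the side chain would also match these two rings remains open. The reading also rests on a single pair of compounds, so it is not known whether the same exchange would give a similar step with a different group elsewhere on the molecule.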